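Benzyl on the ring nitrogen of a thiadiazole hydrazine

A few compounds are considered here, and "the series" means these few. Any claim that something is new, unique, unknown or untested is made for them only; others in the source may bear on it.

Measured compounds:
compound 1, `Cc1ccccc1-c1nnc(N(N)Cc2ccccc2)s1`, 44 mg/kg
compound 2, `Cc1ccccc1-c1nnc(NN(C)C)s1`, only a limit

Compound 1 `Cc1ccccc1-c1nnc(N(N)Cc2ccccc2)s1` was tested in a functional assay on the whole organism with Mus musculus as the target, with a stated time of 1 h (a lower number here means that less compound is needed, a higher number that more compound is needed for the effect), and gives 44 mg/kg. Compound 2 `Cc1ccccc1-c1nnc(NN(C)C)s1` reached only the limit of this assay, > 100 mg/kg, so no number is known for it. For the measured compounds named here, compound 2 is one of the two compounds here and sits at that limit (the limit of > 100 mg/kg in this assay, at which 1 of the 2 values shown sits); no measured step connects it to compound 1.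

Compound 3 `Cc1ccccc1-c1nnc(N(Cc2ccccc2)N(C)C)s1` is not yet measured. Its difference from compound 2 is benzyl in place of hydrogen on a nitrogen on an aromatic ring. Going by the values given here, with compound 2 known only as a limit, the step cannot be placed against a number, and no measured step guides its size. Compound 1 carries the same benzyl on that nitrogen and gives 44 mg/kg, which makes a value in a similar region plausible. Compound 3 is therefore expected to give 60 mg/kg, within 25 mg/kg to 150 mg/kg, an estimated step of an at least 1.6-fold lower number from compound 2 to compound 3 (0.22 log units; that floor lies within the scatter).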

Compound 3, dose for half-maximal effect: > 100 mg/kg
Compound 3 ended at the assay's limit; the forecaster's own chance of this, stated with the estimate: 40%; at least 1.6-fold (0.22 log units) between middle value and limit.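

In this assay, the benzyl on the nitrogen on the aromatic ring is not enough on its own for a readable dose, as it sits in both compound 1 and compound 3. With the benzyl held in place, dimethylamino in place of amino gives an at least 2.2-fold higher number from compound 1 to compound 3 (0.35 log units; beyond the scatter), so the amino group matters in this series. The step from benzyl in place of hydrogen cannot be read, because compound 2 and compound 3 both stand at a limit and not at a number: the limit of > 100 mg/kg in this assay, at which 2 of the 3 values shown sit.

As far as these compounds go, whether methylamino in place of amino would keep a readable dose remains open, as does the effect of a phenethyl group in place of benzyl alongside amino. From the compounds shown here alone, how far apart compound 2 and compound 3 truly lie also stays unknown.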